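Exchanging the hydroxy and methoxy places in compound 2

A few compounds are considered here, and "the series" means these few. Any claim that something is new, unique, unknown or untested is made for them only; others in the source may bear on it.

In a functional assay on HeLa cells (Homo sapiens) for cytotoxicity, read by resazurin assay, with a stated time of 48 h (on this read-out lower numbers stand for stronger inhibition and higher numbers for weaker inhibition), compound 1 (`COc1ccc(Nc2nc(Nc3ccc(Cl)cc3)c(C(=O)c3c[nH]c4ccccc34)s2)cc1`) gives 20000 nM and compound 2 (`COc1cc(/C=C/C(=O)c2sc(Nc3ccc(Cl)cc3)nc2N)ccc1O`) gives 60000 nM. Compound 2 thus holds the higher of the two numbers, a gap beyond the usual scatter. Compound 3 (`COc1ccc(/C=C/C(=O)c2sc(Nc3ccc(Cl)cc3)nc2N)cc1O`) carries 3-hydroxy-4-methoxyphenyl in place of 4-hydroxy-3-methoxyphenyl on a double-bonded chain carbon bound to a double-bonded chain carbon. Among the compounds with values here, no measured pair shows this kind of change, so no shift beyond the scatter is expected in this assay, with an estimated 1.2-fold lower number from compound 2 to compound 3 (0.08 log units; within the scatter). For compound 3, the expected value is 50000 nM, with an estimated range of 20000 nM to 120000 nM.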

Compound 3, half-maximal inhibitory concentration: 30000 nM
Beside the measured number, compound 3's estimate is 1.7-fold (0.22 log units) above it, and the stated range covers the measured number.
By their numbers in this assay, from the lowest: compounds 1, 3 and 2 (each within the scatter of the next, the first and the last beyond it).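

In this assay, putting 3-hydroxy-4-methoxyphenyl in place of 4-hydroxy-3-methoxyphenyl on a double-bonded chain carbon bound to a double-bonded chain carbon gives a 2.0-fold lower number from compound 2 to compound 3 (0.30 log units; within the scatter) and so stays at the edge of the usual scatter. Within the data shown here, this pair is the first direct reading at this position, and it does not separate the two arrangements of hydroxy and methoxy. No supporting measurement bears on this result.

The compounds shown leave open whether an amine or a carboxylic acid in place of the hydroxy group would move the number beyond the scatter. They also leave open what a longer chain in place of the methoxy group would do.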